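Replacing cyclohex-1-en-1-yl with 1H-imidazol-1-yl

A few compounds are considered here, and "the series" means these few. Any claim that something is new, unique, unknown or untested is made for them only; others in the source may bear on it.

In a functional assay on CWR22R cells (Homo sapiens) for antiproliferative activity, read by CCK-8 assay, with a stated time of 6 days (a lower number here means a stronger inhibitor, a higher number a weaker inhibitor), compound 1 `CCN(c1ccc(C#N)c(Cl)c1)c1cc(-c2ccnn2C)ccc1C` gives 4330 nM and compound 2 `CCN(c1ccc(C#N)c(Cl)c1)c1cc(-c2cccs2)ccc1C` gives 22000 nM on the shared core. Within the data shown here, for compound 3 `CCN(c1ccc(C#N)c(Cl)c1)c1cc(C2=CCCCC2)ccc1C` the result stands as "not determined" (no result reported) and so no step can be counted from it. Compound 4 `CCN(c1ccc(C#N)c(Cl)c1)c1cc(-n2ccnc2)ccc1C` carries 1H-imidazol-1-yl in place of cyclohex-1-en-1-yl on an aromatic carbon. Among the measured compounds shown here, the only measured step at this place is a 5.1-fold higher number from compound 1 to compound 2 (0.71 log units; beyond the scatter) and it bears on the change only indirectly, as neither of its groups takes part. No size or direction can be expected from compound 3. The estimate instead leans on compound 1, whose 1-methyl-1H-pyrazol-5-yl is the nearer match to the entering ring. Compound 4 is expected at 6000 nM (estimated range 2000 nM to 20000 nM).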

Compound 4, half-maximal inhibitory concentration: > 30000 nM
Compound 4 ended at the assay's limit; the forecaster's own chance of this, stated with the estimate: 10%; middle value at least 5.0-fold (0.69 log units) away from the limit.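

Compound 4 is read only as a limit of this assay, not as a number: the limit of > 30000 nM in this assay, at which 1 of the 4 values shown sits. Even so, 1H-imidazol-1-yl gives an at least 6.9-fold higher number from compound 1 to compound 4 (0.84 log units; beyond the scatter), which shows that a five-membered aromatic ring at this place does not by itself keep the level of compound 1. Against thiophen-2-yl the reading is an at least 1.3-fold higher number from compound 2 to compound 4 (0.13 log units; that floor lies within the scatter), so no order can be stated there, and no step from compound 3 can be read.

The compounds shown leave open how far past the limit compound 4 lies. They also leave open what a morpholine or a carboxylic acid would do at this place.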